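From hydroxy to methoxymethyl on a shared core

The compounds below may be only part of what the source reports. "The series", "measured", "known", "first", "only" and "open" are said of these compounds alone.

Measured in a functional assay on HCT-116 cells (Homo sapiens) for antiproliferative activity; on this read-out lower numbers stand for stronger inhibition and higher numbers for weaker inhibition:
- Compound 1 `CC(=O)N1CCCc2c(C)c3c(n2-c2ccc(C(N)=O)c(c2)N[C@@H](C)[C@@H]1C)CC(C)(C)CC3=O`: 27 nM
- Compound 2 `Cc1c2c(n3c1CCCN(C(=O)CN)[C@@H](C)[C@H](C)Nc1cc-3ccc1C(N)=O)CC(C)(C)CC2=O`: 147 nM
- Compound 3 `Cc1c2c(n3c1CCCN(C(=O)CO)[C@@H](C)[C@H](C)Nc1cc-3ccc1C(N)=O)CC(C)(C)CC2=O`: 51 nM

Compound 3 sits second highest of the three numbers, but it cannot be separated from compound 1: the record shows a 1.9-fold higher number from compound 1 to compound 3 (0.28 log units; within the scatter). Compound 2 lies further off, with a 2.9-fold lower number from compound 2 to compound 3 (0.46 log units; beyond the scatter).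

The next compound, compound 4 `COCCC(=O)N1CCCc2c(C)c3c(n2-c2ccc(C(N)=O)c(c2)N[C@@H](C)[C@@H]1C)CC(C)(C)CC3=O`, has methoxymethyl in place of hydroxy on a saturated chain carbon bound to a carbonyl carbon.

Among the measured compounds shown here, three measured steps bear on this place. Adding hydroxy to compound 1 stayed within the scatter, while adding amino gave a modest loss, a 5.4-fold higher number from compound 1 to compound 2 (0.74 log units; beyond the scatter). For the measured compounds named here, none of the measured compounds carries methoxymethyl, so these steps offer only a loose guide, and the range must stay wide.

In this assay, the expected result is no change beyond the scatter, with an estimated 1.1-fold higher number from compound 3 to compound 4 (0.03 log units; within the scatter). Compound 4 is estimated at 55 nM, with an expected range of 22 nM to 130 nM.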

Compound 4, half-maximal inhibitory concentration: 55 nM
Beside the measured number, compound 4's estimate shows no gap at the digits printed, and the stated range covers the measured number.
By their numbers in this assay, from the lowest: compounds 1, 3 and 4 (each within the scatter of the next, the first and the last beyond it); then compound 2.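

In this assay, the place on a saturated chain carbon bound to a carbonyl carbon accepts the larger methoxymethyl in place of hydroxy, which removes the hydrogen-bond donor, with a 1.1-fold higher number from compound 3 to compound 4 (0.03 log units; within the scatter) and so no change beyond the scatter. Methoxymethyl also improves on amino, with a 2.7-fold lower number from compound 2 to compound 4 (0.43 log units; beyond the scatter), but compared with hydrogen it gives a 2.0-fold higher number from compound 1 to compound 4 (0.31 log units; beyond the scatter), a modest step beyond the scatter, whereas hydroxy stayed within it. Nothing available accounts for these steps.

The compounds shown leave open how a longer ether chain, a carboxylic acid or a tertiary amine would behave at this place. They also leave open whether these steps would hold on a core other than the shared core.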